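Pyrrolidin-1-yl to piperidin-1-yl: expectation for compound 3

The source may report more compounds than this note shows. Statements on the series, on what has been measured and on what is new or still open speak of the compounds shown alone.

Two compounds of the series have numbers in a functional assay on A549 cells (Homo sapiens) for inhibition, read by MTT assay, with a stated time of 72 h; a higher number here means a weaker inhibitor, a lower number a stronger inhibitor. Compound 1 `c1cc(N2CCCCC2)nc(Nc2ccc(Oc3ncnc4sccc34)cc2)n1` gives 4020 nM. Within the data shown here, compound 2 `CN(c1ccc(Oc2ncnc3sccc23)cc1)c1nccc(N2CCCC2)n1` gives 15100 nM, the highest of the two numbers; compound 1 sits lower, a gap beyond the scatter, but compound 1 differs from compound 2 in more than one place, so no single step is defined between them. Compound 3 `CN(c1ccc(Oc2ncnc3sccc23)cc1)c1nccc(N2CCCCC2)n1` is not yet measured; it differs from compound 2 by piperidin-1-yl in place of pyrrolidin-1-yl on an aromatic carbon. Compound 1 carries the same piperidin-1-yl group, yet without the methyl of compound 2, so its value cannot be read as the outcome of this change alone. The step from compound 2 to compound 3 in this assay is expected to be a modest move toward a lower number, a 1.8-fold lower number from compound 2 to compound 3 (0.25 log units; within the scatter), without being certain to exceed the scatter. For compound 3 an estimate of 8500 nM is made, with a range from 3200 nM to 22000 nM.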

Compound 3, half-maximal inhibitory concentration: 8790 nM
For compound 3 the middle estimate is 1.0-fold (0.01 log units) below the measured one, and the stated range covers the measured number.
By their numbers in this assay, from the lowest: compound 1; then compounds 3 and 2 (each within the scatter of the next).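

In this assay, piperidin-1-yl in place of pyrrolidin-1-yl, on the aromatic carbon next to the ring nitrogen, gives a 1.7-fold lower number from compound 2 to compound 3 (0.23 log units; within the scatter) and so, with the methyl on the nitrogen held constant, the two ring sizes cannot be told apart at this position. Methyl in place of hydrogen on the nitrogen on an aromatic ring can now be read in one place, with piperidin-1-yl held constant: a 2.2-fold higher number from compound 1 to compound 3 (0.34 log units; beyond the scatter) is a modest step, and compound 1 with the hydrogen has the lower number. No measurement at hand accounts for either step.

Open, as far as these compounds go, is how this position responds to morpholin-4-yl or an open-chain dimethylamino group in place of these rings. Also open, from the compounds shown here alone, is whether ethyl on the nitrogen follows the methyl, and whether the methyl step holds with pyrrolidin-1-yl.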